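A Second Chloro Group and Cell Growth Inhibition

The source may hold more compounds than are shown below. What is called first, only, known or untested is meant among the compounds shown, and "the series" means these compounds.

compound 1 `ClCc1ccc(Cn2cnc3c(Cl)ncnc32)cc1`: 310 nM
compound 2 `ClCc1ccccc1Cn1cnc2ncnc(Cl)c21`: 1990 nM
compound 3 `ClCc1ccc(Cn2cnc3c(Cl)nc(Cl)nc32)cc1`: 2340 nM

Of the compounds shown here, three have been measured in a functional assay on ACHN cells (Homo sapiens) for cytotoxicity, read by sulforhodamine B assay, with a stated time of 48 h; a higher number here means a weaker inhibitor of growth, a lower number a stronger inhibitor of growth. Compound 1 `ClCc1ccc(Cn2cnc3c(Cl)ncnc32)cc1` gives the lowest number of the three. Compound 3 `ClCc1ccc(Cn2cnc3c(Cl)nc(Cl)nc32)cc1` differs from compound 1 by one change, (chloro in place of hydrogen on an aromatic carbon), and this change made a step of a 7.5-fold higher number from compound 1 to compound 3 (0.88 log units; beyond the scatter), so the second chloro group weakened growth inhibition here. Compound 2 `ClCc1ccccc1Cn1cnc2ncnc(Cl)c21` has the same atoms as compound 1 joined differently; the difference between the two cores is not broken down here. The values of compound 2 and compound 3 lie within the scatter of each other, so no order can be read between them.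

Compound 4 `ClCc1ccccc1Cn1cnc2nc(Cl)nc(Cl)c21` has not yet been measured. It differs from compound 2 by chloro in place of hydrogen on an aromatic carbon, the same change as that from compound 1 to compound 3, at the same kind of place. If the step repeats on the core of compound 2, compound 4 should give a higher number than compound 2 in this assay. Going by the values given here, because the step of a 7.5-fold higher number from compound 1 to compound 3 (0.88 log units; beyond the scatter) was modest but beyond the scatter, compound 4 is expected to move by about a 5.0-fold higher number from compound 2 to compound 4 (0.70 log units; beyond the scatter), though a single example gives no certainty that the step carries over. Compound 4 is therefore estimated at 10000 nM, with a plausible range from 3000 nM to 30000 nM.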

Compound 4, concentration for 50% growth inhibition: 350 nM
Beside the measured number, compound 4's estimate is 29-fold (1.46 log units) above it; the whole stated range lies above it.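

Placing a chloro group on the aromatic carbon between two ring nitrogen atoms gave a 5.7-fold lower number from compound 2 to compound 4 (0.75 log units; beyond the scatter) in this assay, so on the core of compound 2 the change strengthened growth inhibition, whereas on the core of compound 1 it weakened growth inhibition. The same change therefore did not carry from one core to the other, and the effect seen on one core gave the wrong direction for the other: the same change on two cores in this assay, a 7.5-fold higher number (0.88 log units; beyond the scatter) from compound 1 to compound 3 and a 5.7-fold lower number (0.75 log units; beyond the scatter) from compound 2 to compound 4, 43-fold (1.63 log units) apart, beyond the scatter of two such steps

Going by these compounds alone, this shows that, in these four compounds, the effect of the chloro group depends on the core that carries it, but it does not show why the direction reverses, and with only one pair on each core it sets out no rule for any further core.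

The compounds shown leave open whether this reversal belongs to the chloro group alone or would also appear with another group at the same carbon, such as an amine or a methoxy group. They also leave open whether replacing the chloromethyl group with a longer chain, such as chloropropyl, on each core would preserve the opposite steps seen here.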